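Moving the Amino Group Around the Aryl Ring

The source may report more compounds than this note shows. Statements on the series, on what has been measured and on what is new or still open speak of the compounds shown alone.

Compound 1 `COC(=O)c1sc2cc(-c3cccs3)cnc2c1N` gives 18000 nM in a functional assay on NCI-H460 cells (Homo sapiens) for inhibition, read by sulforhodamine B assay, with a stated time of 48 h; on this read-out lower numbers stand for stronger inhibition of growth and higher numbers for weaker inhibition of growth. Compound 2 `COC(=O)c1sc2cc(-c3cccc(N)c3)cnc2c1N` gives only a limit in this assay, > 150000 nM.

Compound 2 therefore stands at the weaker end of what has been measured; its result is a limit, not a number, and the limit of > 150000 nM in this assay, at which 1 of the 2 values shown sits, marks where it sits. For the measured compounds named here, compound 3 `COC(=O)c1sc2cc(-c3ccc(N)cc3)cnc2c1N` is the only unmeasured compound here. It differs from compound 2 by 4-aminophenyl in place of 3-aminophenyl on an aromatic carbon; the two share every atom and differ only in where the amino group sits on the pendant ring.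

Going by the values given here, one measured step touches this position: an at least 8.3-fold higher number from compound 1 to compound 2 (0.92 log units; beyond the scatter). That step swapped the whole aryl group rather than shifting a substituent within it, so it does not speak directly to the change from compound 2 to compound 3. Nothing in the measured pairs tests a shift of the amino group. The expectation for compound 3 is thus a step of a number no higher from compound 2 to compound 3 (the limit leaves the size open) in this assay, with a sizeable chance that the assay again returns only a limit. The estimate for compound 3 is 150000 nM, ranging from 40000 nM to 600000 nM.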

Compound 3, concentration for 50% growth inhibition: 37100 nM
Beside the measured number, compound 3's estimate is 4.0-fold (0.61 log units) above it, and the stated range ends above it.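

For the compounds shown here, compound 3 tests what the earlier compounds could not: whether the place of the amino group on the pendant ring matters in this assay. It does, with 4-aminophenyl in place of 3-aminophenyl giving an at least 4.0-fold lower number from compound 2 to compound 3 (0.60 log units; beyond the scatter). Compound 2 gives only a limit, so this step has a floor and no exact size: the limit of > 150000 nM in this assay, at which 1 of the 3 values shown sits. Set against the thiophen-2-yl group, 4-aminophenyl gives a 2.1-fold higher number from compound 1 to compound 3 (0.31 log units; beyond the scatter), a modest step, so the large loss seen with 3-aminophenyl does not hold for every aminophenyl group at this carbon.

The compounds shown leave open what the amino group itself contributes, as a plain phenyl ring, or a phenyl ring carrying a hydroxyl or methoxy group in the same place, would be needed to separate it from the phenyl ring that carries it. They also leave open how 2-aminophenyl would read, and whether any aryl group at this carbon would give a lower number than the thiophen-2-yl group of compound 1.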